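The source may report more compounds than this note shows. Statements on the series, on what has been measured and on what is new or still open speak of the compounds shown alone.

In a functional assay on BT-549 cells (Homo sapiens) for cytotoxicity, read by MTT assay, with a stated time of 48 h (on this read-out higher numbers stand for weaker inhibition and lower numbers for stronger inhibition), compound 1 (`COc1cc(/C=C2\C(=O)Nc3ccccc32)ccc1OCCCN1CCN(c2ccccn2)CC1`) gives > 20000 nM, which is a limit and not a number. Compound 2 (`COc1cc(/C=C2\C(=O)Nc3ccc(Cl)cc32)ccc1OCCCN1CCN(c2ccccn2)CC1`) gives > 20000 nM, also a limit. Compound 3 (`COc1cc(/C=C2\C(=O)Nc3ccc(C)cc32)ccc1OCCCN1CCN(c2ncccc2C(F)(F)F)CC1`) gives > 20000 nM, again a limit. Compound 2 therefore has no readable value and stands with the others at the limit of > 20000 nM in this assay, at which 3 of the 3 values shown sit.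

Compound 4 (`COc1cc(/C=C2\C(=O)Nc3ccc(Cl)cc32)ccc1OCCCN1CCN(C)CC1`) carries methyl in place of pyridin-2-yl on an amine nitrogen in a ring. Within the data shown here, the only measured step, a step that the two limits leave unreadable from compound 1 to compound 2, concerns a different change and gives no size to carry over. No direction can be read from it, so the expectation rests on (the limit of > 20000 nM in this assay, at which 3 of the 3 values shown sit). The expected change is a number no higher from compound 2 to compound 4 (the limit leaves the size open). Compound 4 is estimated at 20000 nM, with an expected range of 8000 nM to 50000 nM.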

Compound 4, half-maximal inhibitory concentration: 2170 nM
Compound 4: the middle estimate sits 9.2-fold (0.96 log units) above what was measured, and the stated range ends above it.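

Methyl in place of pyridin-2-yl on the amine nitrogen gives an at least 9.2-fold lower number from compound 2 to compound 4 (0.96 log units; beyond the scatter) in this assay, which makes this position the only place among the compounds shown where a change has a readable size. Compound 4 carries a measured number, while the other compounds remain at a limit: the limit of > 20000 nM in this assay, at which 3 of the 4 values shown sit.

On these data alone, whether methyl itself matters or only the loss of pyridin-2-yl remains open; an ethyl group or a plain hydrogen on that nitrogen would separate the two. As far as these compounds go, whether methyl needs the chloro on the core also remains open.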